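The compounds below may be only part of what the source reports. "The series", "measured", "known", "first", "only" and "open" are said of these compounds alone.

In a functional assay on PC-6 cells (Homo sapiens) for antiproliferative activity (on this read-out lower numbers stand for stronger inhibition and higher numbers for weaker inhibition), compound 1 `CCc1cc2c(N/N=C\C(C)(C)C)ncnc2s1` gives 1.55 ug/mL, while compound 2 `CC(C)c1cc2c(N/N=C\c3ccccn3)ncnc2s1` gives 0.003 ug/mL, the lowest of the two numbers and a gap from compound 1 that lies well beyond the usual scatter. Compound 3 `CC(C)c1cc2c(N/N=C\c3ccco3)ncnc2s1` keeps the core of compound 2 but carries furan-2-yl in place of pyridin-2-yl on a carbon with a double bond to nitrogen. Among the measured compounds shown here, no measured pair shows this exact change, so the step from compound 2 to compound 3 is expected to weaken inhibition, by roughly a 33-fold higher number from compound 2 to compound 3 (1.52 log units; beyond the scatter). Compound 3 is therefore estimated at 0.1 ug/mL in this assay, with a likely range from 0.01 ug/mL to 1 ug/mL.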

Compound 3, half-maximal inhibitory concentration: 3.78 ug/mL
The estimate for compound 3 lay 38-fold (1.58 log units) below the measured number, and the stated range ends below it.
By their numbers in this assay, from the lowest: compound 2; then compound 1; then compound 3.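

On the carbon with a double bond to nitrogen, furan-2-yl in place of pyridin-2-yl gives in this assay a 1300-fold higher number from compound 2 to compound 3 (3.10 log units; beyond the scatter). This is a large step, beyond the usual scatter, so the read-out depends strongly on which ring sits at this position. The two rings have the same counts of hetero atoms and hydrogen-bond acceptors, so those counts do not separate them, and no evidence here explains the step.

On these data alone, how phenyl or pyridin-3-yl would fare on this carbon remains open. So does whether the same step would appear with another group on the shared core.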